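Aryl exchange from compound 2 to compound 4

The source may report more compounds than this note shows. Statements on the series, on what has been measured and on what is new or still open speak of the compounds shown alone.

Measured so far in a functional assay on QGY-7703 cells (Homo sapiens) for cytotoxicity, read by MTT assay, with a stated time of 24 h; on this read-out higher numbers stand for weaker inhibition and lower numbers for stronger inhibition
- compound 1 (`COc1cc(/C=C2\CN(C)C/C(=C\c3cccnc3)C2=O)cc(OC)c1OC`) gives 4300 nM
- compound 2 (`CN1C/C(=C\c2cccnc2)C(=O)/C(=C/c2ccccc2F)C1`) gives 4470 nM
- compound 3 (`CN1C/C(=C\c2cccnc2)C(=O)/C(=C/c2cc([N+](=O)[O-])ccc2F)C1`) gives 11100 nM

Compound 2 lies within the scatter of compound 1 and below compound 3. For the measured compounds named here, compound 4 (`CN1C/C(=C\c2ccc(C#N)cc2)C(=O)/C(=C/c2cccnc2)C1`) has no measurement yet. Its difference from compound 2 is 4-cyanophenyl in place of 2-fluorophenyl on a double-bonded chain carbon bound to a double-bonded ring carbon. Going by the values given here, no measured step makes this exchange. The nearest is a 2.5-fold higher number from compound 2 to compound 3 (0.40 log units; beyond the scatter), a modest step with nitro in place of hydrogen on an aromatic carbon. Compound 1, at 4300 nM, carries a different aromatic group yet stays within the scatter of compound 2. A small upward step in this assay is therefore expected, smaller than that modest one. The expected step is a 1.3-fold higher number from compound 2 to compound 4 (0.13 log units; within the scatter). For compound 4 the estimate is 6000 nM, with an estimated range from 2500 nM to 14000 nM.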

Compound 4, half-maximal inhibitory concentration: > 20000 nM
Compound 4: no number, only a limit; the forecaster's own chance of this, stated with the estimate: 3%; middle value at least 3.3-fold (0.52 log units) away from the limit.
By their numbers in this assay, from the lowest: compounds 1 and 2 (each within the scatter of the next); then compound 3. At a limit, above all of these: compound 4.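

In this assay, 4-cyanophenyl in place of 2-fluorophenyl on a double-bonded chain carbon bound to a double-bonded ring carbon gives an at least 4.4-fold higher number from compound 2 to compound 4 (0.65 log units; beyond the scatter). For the compounds shown here, compounds 1 and 2 carry different aromatic groups here and stay within the scatter of each other, so the new step is the first sign that this position does not accept every aryl group equally. Compound 4 gives a limit, not a number: the limit of > 20000 nM in this assay, at which 1 of the 4 values shown sits.

As far as these compounds go, whether the nitrile or the loss of fluorine carries the step remains open. A plain phenyl, or an amine or carboxylic acid in place of the nitrile, would help separate the two.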